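The compounds below may be only part of what the source reports. "The series", "measured", "known", "first", "only" and "open" are said of these compounds alone.

Compounds measured in a functional assay on HEK293 cells for agonist activity at D(4) dopamine receptor (Homo sapiens), read by FLIPR; a lower number here means that less compound is needed, a higher number that more compound is needed for the effect:
Compound 1, `Cc1cc(NC(=O)CN2CCC(c3cccc[n+]3[O-])CC2)ccc1F`: 18 nM
Compound 2, `O=C(CN1CCC(c2cccc[n+]2[O-])CC1)NC1CCCCC1`: 294 nM
Compound 3, `COc1cccc(C)c1NC(=O)CN1CCC(c2cccc[n+]2[O-])CC1`: 340 nM

All three share one core, and the three differ only in the group on the amide-type nitrogen. Compound 3 gives the highest of the three numbers in this assay, but its gap to compound 2 lies within the usual scatter; only compound 1 stands clearly apart from it, beyond the scatter.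

Among the measured compounds shown here, the only step with a single change is a 16-fold higher number from compound 1 to compound 2 (1.21 log units; beyond the scatter), which exchanges the whole group on the amide-type nitrogen. It is a large step, yet it concerns a different part of the molecule from the change now in question.

Compound 4, `Cc1cccc(C)c1NC(=O)CN1CCC(c2cccc[n+]2[O-])CC1`, has not been measured. It differs from compound 3 in one place: methyl in place of methoxy on an aromatic carbon. For the measured compounds named here, no measured step touches this aromatic carbon, so nothing in the data speaks for a shift in either direction. Compound 4 is therefore expected to give a number close to that of compound 3 in this assay, with an estimated step of a 1.1-fold lower number from compound 3 to compound 4 (0.05 log units; within the scatter), not beyond the scatter. The estimate for compound 4 is 300 nM, with a range from 100 nM to 900 nM.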

Compound 4, half-maximal effective concentration: 346 nM
Compound 4: the middle estimate sits 1.2-fold (0.06 log units) below what was measured; low and high end bracket the measured number.
By their numbers in this assay, from the lowest: compound 1; then compounds 2, 3 and 4 (each within the scatter of the next).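

In this assay, among the compounds shown here, the first comparison at this aromatic carbon, a 1.0-fold higher number from compound 3 to compound 4 (0.01 log units; within the scatter), lies within the scatter, so methoxy and methyl cannot be told apart here, even though the change removes a heavy atom and a hydrogen-bond acceptor. The new compound also ties the aryl series to the earlier cyclohexyl result: 2,6-dimethylphenyl in place of cyclohexyl on the amide-type nitrogen gives a 1.2-fold higher number from compound 2 to compound 4 (0.07 log units; within the scatter), again within the scatter, whereas 2,6-dimethylphenyl in place of 4-fluoro-3-methylphenyl gives a 19-fold higher number from compound 1 to compound 4 (1.28 log units; beyond the scatter), a large step beyond it, so among these compounds a six-membered aromatic ring of carbon only on that nitrogen does not by itself go with the low number of compound 1, as compound 3 and compound 4 show. Nothing available offers an explanation for these numbers.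

Going by these compounds, it remains open whether a quite different group on this aromatic carbon, such as an amine, a carboxylic acid or a longer chain, would stand apart from methoxy and methyl. Also open, on these data alone, is which part of 4-fluoro-3-methylphenyl, the fluoro or the methyl group, goes with the low number of compound 1.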